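The compounds below may be only part of what the source reports. "The series", "measured", "known", "first", "only" and "open" are said of these compounds alone.

Compound 2 `CCCNC(=O)NS(=O)(=O)c1ccc(-n2nc(-c3ccc(C)cc3)ccc2=O)cc1` is read in a functional assay on the whole organism (blood, strain Wistar albino) for inhibition, with Rattus norvegicus as the target, read by colorimetric assay, with stated times of 15 min and 90 min, at a dose of 20 mg/kg by the oral route (a higher number here means more inhibition at the dose given (going by the name of the read-out), a lower number less inhibition), and there compound 2 gives 109%. Two other compounds share its core. Compound 1 `CCCNC(=O)NS(=O)(=O)c1ccc(-n2nc(-c3ccccc3)ccc2=O)cc1` gives 125% in this assay, and compound 3 `CCCCNC(=O)NS(=O)(=O)c1ccc(-n2nc(-c3ccc(C)cc3)ccc2=O)cc1` gives 109%. Among these three numbers compound 2 stands level with compound 3, the two together being the lowest, while compound 1 lies higher. The measured steps joining them are a number 16 percentage points lower from compound 1 to compound 2 (beyond the scatter) and no change at the digits printed from compound 2 to compound 3 (within the scatter). Compound 4 `CCCNC(=O)NS(=O)(=O)c1ccc(-n2nc(-c3ccc(Cl)cc3)ccc2=O)cc1` differs from compound 2 by chloro in place of methyl on an aromatic carbon. Going by the values given here, of the two measured steps, only the one from compound 1 to compound 2 touches an aromatic carbon, and it moved the read-out modestly; the one on the chain did not move it beyond the scatter. Neither step exchanges one aromatic substituent for another, so nothing measured fixes the direction of the present change. A small step is therefore expected, a number 1 percentage points higher from compound 2 to compound 4 (within the scatter). Compound 4 is estimated to give 110%, within a range of 92% to 128%.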

Compound 4, a percentage reported as inhibition, in the whole organism at one dose (the size of the read-out at that dose, not a potency): 122%
For compound 4 the middle estimate is 12 percentage points below the measured one; the measured number falls inside the stated range.
By their numbers in this assay, from the lowest: compounds 2 and 3 (each within the scatter of the next); then compounds 4 and 1 (each within the scatter of the next).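

At this aromatic carbon, para to a large group, the read-out in this assay depends on which group is present: chloro in place of methyl gives a number 13 percentage points higher from compound 2 to compound 4 (beyond the scatter) and so reverses the effect of the methyl group seen in a number 16 percentage points lower from compound 1 to compound 2 (beyond the scatter) in this series. Chloro in place of hydrogen gives a number 3 percentage points lower from compound 1 to compound 4 (within the scatter) and thus no separation beyond the scatter, so among the three groups shown here only methyl stands apart. Nothing available explains this difference between methyl and chloro.

From the compounds shown here alone, whether a methoxy, fluoro or trifluoromethyl group at this carbon would read with hydrogen and chloro or with methyl remains open. Also open, going by these compounds, is whether the butyl chain, which made no difference beside the 4-methylphenyl group, would behave the same way beside the 4-chlorophenyl group.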